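Halogen for methyl on the shared core: cytotoxicity notes

This account rests on a few compounds, and the source may have more. Where it says the series, first, only, none or still open, it means among the compounds named here.

Measured compounds:
- compound 1, `CCn1c(/C=C2/C(=O)Nc3ccc(C)cc32)nc2ccccc21`: 39400 nM
- compound 2, `Cn1c(/C=C2/C(=O)Nc3ccc(Br)cc32)nc2ccccc21`: > 50000 nM
- compound 3, `Cn1c(/C=C2/C(=O)Nc3ccc(F)cc32)nc2ccccc21`: 29600 nM

In a functional assay on 4T1 cells (Homo sapiens) for cytotoxicity, read by MTT assay, with a stated time of 48 h (a higher number here means a weaker inhibitor, a lower number a stronger inhibitor), compound 1 gives 39400 nM, the highest of the two numbers shown. Compound 3 gives 29600 nM, and the gap between compound 1 and compound 3 lies within the scatter, so no order can be read from it. Compound 2 reaches only a limit of this assay, > 50000 nM, and no number is known for it (the limit of > 50000 nM in this assay, at which 1 of the 3 values shown sits).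

For the measured compounds named here, the one measured step is an at least 1.6-fold lower number from compound 2 to compound 3 (0.22 log units; that floor lies within the scatter); its floor sits within the scatter, so it points, if anywhere, only weakly toward a lower number with the smaller halogen.

Compound 4, `CCn1c(/C=C2/C(=O)Nc3ccc(Cl)cc32)nc2ccccc21`, differs from compound 1 as follows: chloro in place of methyl on an aromatic carbon. Going by the values given here, no measured step matches this change. Chloro is a halogen, as in compound 2 and compound 3, and the shown step from those two compounds bears on it only indirectly. The expected step of a 1.1-fold higher number from compound 1 to compound 4 (0.06 log units; within the scatter) is therefore small, with a modest pull toward a higher number and a real chance of a limit. Compound 4 is estimated at 45000 nM, with a range from 20000 nM to 100000 nM.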

Compound 4, half-maximal inhibitory concentration: > 50000 nM
Compound 4: no number, only a limit; the forecaster's own chance of this, stated with the estimate: 40%; middle value at least 1.1-fold (0.04 log units) from the limit.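

For the compounds shown here, with chloro in place of methyl on this aromatic carbon, the step reads an at least 1.2-fold higher number from compound 1 to compound 4 (0.10 log units; that floor lies within the scatter), which gives the first comparison of a halogen with methyl on one shared core, where the earlier step compared only one halogen with another. Going by these compounds, the floor of that step gives no firm order between methyl and chloro at this carbon, and the full size of the step stays unknown. In this assay compound 4 gives a limit and not a number, so limits now account for a larger share of the series: the limit of > 50000 nM in this assay, at which 2 of the 4 values shown sit.

On these data alone, compound 4 and compound 3 differ in more than one place, so these values give no reading of chloro against fluoro, and the effect of fluoro on the core of compound 1 stays open. Also open, as far as these compounds go, is whether a group of a different kind on this aromatic carbon, such as an amine or a carboxylic acid, would give a number clearly apart from that of compound 1 in this assay.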